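The source may report more compounds than this note shows. Statements on the series, on what has been measured and on what is new or still open speak of the compounds shown alone.

Measured so far: compound 1 `Cc1ccccc1CNC(=O)C(=O)N[C@@H](C)C(=O)N[C@@H](CC(=O)O)C(=O)COc1c(F)c(F)cc(F)c1F` gives 52 nM in a functional assay on Jurkat cells (Homo sapiens); a higher number here means a weaker inhibitor, a lower number a stronger inhibitor; compound 2 `C[C@H](NC(=O)C(=O)NCc1ccc(F)cc1)C(=O)N[C@@H](CC(=O)O)C(=O)COc1c(F)c(F)cc(F)c1F` gives 197 nM in this assay.

Compound 2 stands at the highest of the two numbers, with compound 1 the nearest, at a 3.8-fold higher number from compound 1 to compound 2 (0.58 log units; beyond the scatter). Compound 3 `C[C@H](NC(=O)C(=O)NCc1ccc(Cl)cc1Cl)C(=O)N[C@@H](CC(=O)O)C(=O)COc1c(F)c(F)cc(F)c1F` is not yet measured in this assay. It differs from compound 2 in one place: 2,4-dichlorophenyl in place of 4-fluorophenyl on a saturated chain carbon bound to an amide-type nitrogen. Within the data shown here, the one measured step that bears on this change is the one from compound 1 to compound 2, at a 3.8-fold higher number from compound 1 to compound 2 (0.58 log units; beyond the scatter), which shows that the group on the saturated chain carbon bound to the amide-type nitrogen shifts the number by a modest amount. Since compound 1 carries 2-methylphenyl and compound 3 carries 2,4-dichlorophenyl, a step toward compound 1 is expected, of roughly a 2.5-fold lower number from compound 2 to compound 3 (0.39 log units; beyond the scatter). Compound 3 is therefore estimated at 80 nM, within a range of 25 nM to 260 nM.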

Compound 3, half-maximal inhibitory concentration: 165 nM
Compound 3: the middle estimate sits 2.1-fold (0.31 log units) below what was measured; the range from low to high includes it.
By their numbers in this assay, from the lowest: compound 1; then compounds 3 and 2 (each within the scatter of the next).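

In this assay, the 2,4-dichlorophenyl group of compound 3 and the 4-fluorophenyl group of compound 2 cannot be told apart (a 1.2-fold lower number from compound 2 to compound 3 (0.08 log units; within the scatter)), so this change, with its extra heavy atom and two chlorines for one fluorine, leaves the number within the scatter. The 2-methylphenyl group of compound 1 now stands apart from two different halogenated phenyl groups at this position, with the second comparison reading (a 3.2-fold higher number from compound 1 to compound 3 (0.50 log units; beyond the scatter)), and so the step to compound 1 is not specific to the 4-fluorophenyl group. No measurement shown here accounts for these differences.

The compounds shown leave open whether the methyl group alone sets compound 1 apart, which a 2-chlorophenyl, 4-methylphenyl or unsubstituted phenyl group at this position would test. They also leave open whether a ring is needed here at all, as a cyclohexyl group or a longer chain would show.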